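From compound 2 to compound 3, with limits only

The compounds below may be only part of what the source reports. "The series", "measured", "known", "first", "only" and "open" are said of these compounds alone.

Compound 1 `Cc1ccc(NC(=O)Nc2cc(C)nc3ccccc23)cc1` gives > 25000 nM as a limit
Compound 2 `Cc1cc(NC(=O)Nc2cccc(F)c2)c2ccccc2n1` gives > 25000 nM as a limit

In an ADME assay on Raji cells (Homo sapiens) for cytotoxicity, with a stated time of 72 h (on this read-out lower numbers stand for an effect already at smaller amounts and higher numbers for an effect only at larger amounts of compound), compound 2 gives > 25000 nM as a limit of the assay and not a number. Compound 2 and compound 1 share the limit of > 25000 nM in this assay, at which 2 of the 2 values shown sit, and neither has a number of its own.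

Compound 3 `Cc1cc(NC(=O)Nc2ncccc2C)c2ccccc2n1` changes one group on an amide-type nitrogen, with 3-methylpyridin-2-yl in place of 3-fluorophenyl (3-methylpyridin-2-yl in place of 3-fluorophenyl on an amide-type nitrogen).

Only the measured step that the two limits leave unreadable from compound 1 to compound 2 bears on this change, as it too falls on an amide-type nitrogen, and it offers no size to carry over. Given the limit of > 25000 nM in this assay, at which 2 of the 2 values shown sit, for compound 1 and compound 2, no step beyond the scatter is expected in this assay in either direction. The estimated step is a step that the limit leaves unreadable from compound 2 to compound 3 and no more can be expected from these data. For compound 3 the estimate is 30000 nM with an expected range from 12000 nM to 60000 nM and a report of only a limit is the likeliest outcome.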

Compound 3, half-maximal effective concentration: > 25000 nM
Compound 3: a limit, no number (the forecaster's own chance of this, stated with the estimate: 80%); the middle value is on the limit's open side.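

No new step can be read among compound 1, compound 2 and compound 3 in this assay, and all three results are limits and not numbers: the limit of > 25000 nM in this assay, at which 3 of the 3 values shown sit.

The compounds shown leave open whether 4-methylphenyl, 3-fluorophenyl and 3-methylpyridin-2-yl on an amide-type nitrogen differ at all in this assay.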